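Dropping the fluoro from the benzyl group of compound 1

The compounds below may be only part of what the source reports. "The series", "measured", "known", "first", "only" and "open" are said of these compounds alone.

Within the data shown here, compound 1 `Nc1n[nH]c2cc(-c3ccc(=O)n(Cc4ccccc4F)c3)ccc12` is the only compound with a number in an assay for inhibition of MAP kinase-interacting serine/threonine-protein kinase 2 (Homo sapiens), read by luminescence and ADP-Glo, with a stated time of 2 h; a higher number here means a weaker inhibitor, a lower number a stronger inhibitor: compound 1 gives 4 nM. Compound 2 `O=C(N1CCOCC1)n1cc(-c2ccc3cn[nH]c3c2)ccc1=O` reaches only a limit of this assay, and in this assay compound 2 gives > 2000 nM. Compound 3 `Nc1n[nH]c2cc(-c3ccc(=O)n(Cc4ccccc4)c3)ccc12` differs from compound 1 by hydrogen in place of fluoro on an aromatic carbon. Among the measured compounds shown here, no step between two measured compounds covers this change, so it is judged on its own. A step of a 1.5-fold higher number from compound 1 to compound 3 (0.18 log units; within the scatter) is expected, which stays within the usual scatter. Compound 3 is therefore estimated at 6 nM, in the range 2 nM to 20 nM.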

Compound 3, half-maximal inhibitory concentration: 32 nM
Compound 3: middle estimate off by 5.3-fold (0.73 log units), on the low side; the measured number lies above the stated range.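

In this assay, replacing the 2-fluorobenzyl group with benzyl gives an 8.0-fold higher number from compound 1 to compound 3 (0.90 log units; beyond the scatter), so the fluoro on this aromatic carbon, ortho to a large group, matters in this assay. Among these compounds, this is the first measured change at this position, and it shows that this single atom carries a real part of the potency of compound 1. Nothing shown accounts for the size of this step. From the compounds shown here alone, whether chloro, methyl or methoxy at this carbon would match fluoro remains open, as does the effect of fluoro on the other carbons of this ring.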